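The compounds below may be only part of what the source reports. "The series", "measured", "known", "first", "only" and "open" are said of these compounds alone.

Measured compounds:
compound 1 `C[C@]1(C(=O)O)CSC(c2ccc(O)cc2O)=N1` — -1.05
compound 2 `COc1ccc(C2=N[C@@H](C(=O)O)CS2)c(O)c1` — -0.89

Two compounds have been run in a physicochemical assay for lipophilicity; a higher number here means a more lipophilic compound, a lower number a more polar compound. Compound 1 gives -1.05 in this assay, and compound 2 gives -0.89. The two numbers lie within the usual scatter of each other, so compound 1 cannot be set apart from compound 2 on these numbers; both are distinctly polar compounds.

Compound 3 `COc1ccc(C2=N[C@@](C)(C(=O)O)CS2)c(O)c1` is not yet measured. It differs from compound 1 in one place: methyl in place of hydrogen on an oxygen on an aromatic ring, which, cut one bond further out, reads hydroxy to methoxy. For the measured compounds named here, no measured pair shows this exact change alone, so its size here is not known from the data. Such a step is generally expected to push this assay upward by a modest amount, possibly just beyond the scatter. Compound 3 is therefore expected to give -0.6 in this assay, with a range from -1 to -0.2. The expected step from compound 1 to compound 3 is a number 0.45 log units higher from compound 1 to compound 3 (beyond the scatter).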

Compound 3, partition coefficient: -0.7
Estimate against measurement, compound 3: 0.10 log units above; the measured number falls inside the stated range.
By their numbers in this assay, from the lowest: compounds 1, 2 and 3 (each within the scatter of the next, the first and the last beyond it).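

In this assay, for the compounds shown here, replacing hydroxy with methoxy on the aromatic ring gives a number 0.35 log units higher from compound 1 to compound 3 (beyond the scatter), and this is the first change in the set that can be read on its own, as compound 1 and compound 3 differ only in this place. The step is modest, yet it stands clear of the usual scatter, while compound 3 at -0.7 still has a negative number. Nothing available here gives a reason for the size of this step.

One step at one place cannot show how the number would respond to a longer chain on that oxygen, such as ethyl or propyl. It also leaves open what an amine in place of the hydroxy would do to the number.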